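A few compounds are considered here, and "the series" means these few. Any claim that something is new, unique, unknown or untested is made for them only; others in the source may bear on it.

Series notes. Within the data shown here, the three compounds measured so far share one core, carried in compound 1 `Cn1cc(-c2ccccc2)nc1NC(=O)c1ccc(F)cc1`, compound 2 `COc1ccc(-c2cnc(NC(=O)c3ccc(O)cc3)n2C)cc1` and compound 3 `Cn1c(-c2ccccc2)cnc1NC(=O)c1ccccc1Cl`. All three were run in a toxicity assay on THP-1 cells (Homo sapiens) for inhibition; a higher number here means that more compound is tolerated, a lower number that less compound is tolerated. Compound 1 reaches only a limit of the assay, > 50000 nM. Compound 3 likewise returns only a limit, > 50000 nM. Compound 2 also gives only a limit, > 100000 nM. So none of the three yields a number: compound 2 sits at the limit of > 100000 nM in this assay, at which 1 of the 3 values shown sits, while compound 1 and compound 3 sit at the limit of > 50000 nM in this assay, at which 2 of the 3 values shown sit. Among the measured compounds shown here, no ordering among the three can be read from limits, and the set holds no step between measured compounds that differ in one place.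

Compound 4 `COc1ccc(-c2cnc(NC(=O)C3CCCC3)n2C)cc1` is the next compound and is still to be measured in this assay. It differs from compound 2 in one place: cyclopentyl in place of 4-hydroxyphenyl on a carbonyl carbon.

For the measured compounds named here, with every measured compound at a limit and no measured step to lean on, the expected step is a number no higher from compound 2 to compound 4 (the limit leaves the size open), which is to say none beyond the scatter. In this assay compound 4 is expected to come out near 100000 nM, with a likely range from 30000 nM to 300000 nM, and the reading is expected most likely to be a limit once more.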

Compound 4, half-maximal cytotoxic concentration: > 100000 nM
Compound 4: only a limit was reported; the forecaster's own chance of this, stated with the estimate: 85%; the middle value lies on the limit itself.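

Compound 2 and compound 4 both return only a limit, so no step between them can be read: the limit of > 100000 nM in this assay, at which 2 of the 4 values shown sit.

The compounds shown leave open whether any member of the series gives a number in this assay, and so whether cyclopentyl in place of 4-hydroxyphenyl on a carbonyl carbon changes the reading at all.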